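Swapping 4-ethylphenyl for naphthalen-1-yl on a sulfur

The source may report more compounds than this note shows. Statements on the series, on what has been measured and on what is new or still open speak of the compounds shown alone.

Compound 1 (`CCc1ccc(SCc2ccc(/C=C/C(=O)Nc3ccccc3N)cc2)cc1`) has been measured in a functional assay on A549 cells (Homo sapiens) for inhibition, read by CCK-8 assay, with a stated time of 72 h, tested at 8 uM (a higher number here means more inhibition of growth at the concentration tested, a lower number less inhibition of growth), where compound 1 gives 68.6%. Among the measured compounds shown here, the only other measured compound is compound 2 (`CCc1ccc(SCc2ccc(C(=O)Nc3ccccc3N)cc2)cc1`), and in this assay compound 2 gives 91.4%. Compound 1 therefore holds the lower of the two numbers, and the gap between them lies beyond the usual scatter of such measurements.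

Compound 3 (`Nc1ccccc1NC(=O)/C=C/c1ccc(CSc2cccc3ccccc23)cc1`) has not been measured yet. It keeps the core of compound 1 and alters one group: naphthalen-1-yl in place of 4-ethylphenyl on a sulfur. The sulfur's other neighbour, a saturated chain carbon, stays as it was.

For the measured compounds named here, no measured pair yet shows what a swap of this kind does, so the best starting point is compound 1 at 68.6%. No change beyond the scatter is expected in either direction, and the estimated step of a number 1.4 percentage points higher from compound 1 to compound 3 (within the scatter) is a small one. The expected value for compound 3 is 70%, with an estimated range from 48% to 88%.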

Compound 3, percent growth inhibition at one concentration: 71.2%
For compound 3 the middle estimate is 1.2 percentage points below the measured one, within the range that was stated.
By their numbers in this assay, from the lowest: compounds 1 and 3 (each within the scatter of the next); then compound 2.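

In this assay, among the compounds shown here, the step for naphthalen-1-yl in place of 4-ethylphenyl on a sulfur is a number 2.6 percentage points higher from compound 1 to compound 3 (within the scatter), the first direct reading of a change at this position. It shows that the group on the sulfur can go from one six-membered aromatic ring of carbon only to two, with no difference that can be told from the scatter in this growth read-out, so this position accepts at least this one larger aromatic group in the core of compound 1. The data offer no measured explanation for this result, and a single pair of compounds cannot show how far such tolerance extends.

Going by these compounds, both groups seen on this sulfur are built of carbon alone and carry no charge, so it remains open whether a saturated cyclohexyl ring, or an aromatic ring bearing an amine or a carboxylic acid, would give a similar number. The read-out also comes from one cell line at a single concentration, which leaves open whether compound 1 and compound 3 would still match across a range of concentrations or in other cells.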